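From Cyclohexyl to Piperidin-1-yl on a Saturated Chain

This account rests on a few compounds, and the source may have more. Where it says the series, first, only, none or still open, it means among the compounds named here.

Of the compounds shown here, three have so far been measured in a physicochemical assay for lipophilicity; on this read-out higher numbers stand for higher lipophilicity and lower numbers for lower lipophilicity. Compound 3 (`c1ccc(COCCCCC2CCCCC2)cc1`) gives 6.6 and compound 1 (`c1ccc(CCCC2CCCCC2)cc1`) gives 6.6 at the digits reported, so the two stand level, within the scatter, and share the highest number of the three. Compound 2 (`c1ccc(CCON2CCCCC2)cc1`) gives 4.8 and lies well beyond the scatter from that pair.

Compound 4 (`c1ccc(COCCCCN2CCCCC2)cc1`) has not yet been measured. Compared with compound 3, it has piperidin-1-yl in place of cyclohexyl on a saturated chain carbon, four bonds along the chain from an oxygen on a saturated carbon.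

Within the data shown here, no measured pair shows this swap alone. Among the measured compounds shown here, the only hint is that compound 2, which carries piperidin-1-yl, gives 4.8 while compound 1, which carries cyclohexyl, gives 6.6 in this assay and also differs from it elsewhere. A fall beyond the scatter of similar size is expected, estimated as a number 1.90 log units lower from compound 3 to compound 4 (beyond the scatter) in this read-out. For compound 4 the estimated value is 4.7 (expected range 4.1 to 5.3).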

Compound 4, partition coefficient: 5.8
Compound 4: the middle estimate sits 1.10 log units below what was measured; measured number outside the range, above it.
By their numbers in this assay, from the lowest: compound 2; then compound 4; then compounds 1 and 3 (each within the scatter of the next).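

Among these compounds, this pair gives the first direct reading of the swap, as no earlier pair differed in this one place: with piperidin-1-yl in place of cyclohexyl on a saturated chain carbon, four bonds along the chain from an oxygen on a saturated carbon, this assay gives a number 0.80 log units lower from compound 3 to compound 4 (beyond the scatter). Both groups hold 6 heavy atoms, and the leaving and entering groups differ in 1 nitrogen taking the place of a carbon, with 1 hydrogen-bond acceptor gained. Nothing measured here explains the size of this step.

Among the compounds shown here, with only this one pair, it remains open whether the step would carry over to any other chain, such as a longer chain between the oxygen and the ring. Also open, from the compounds shown here alone, is how a morpholin-4-yl group or an open-chain diethylamino group would read at this same place.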